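Replacing an Ester Chain with a Trimethoxyphenyl Ring

This account rests on a few compounds, and the source may have more. Where it says the series, first, only, none or still open, it means among the compounds named here.

The series shares one core, seen in compound 1 `COC(=O)CN(C)c1nc(Nc2cccc(OC)c2)ncc1[N+](=O)[O-]`, compound 2 `CCOC(=O)CN(Cc1ccccc1)c1nc(NCc2ccccc2)ncc1[N+](=O)[O-]` and compound 3 `CCOC(=O)CNc1ncc([N+](=O)[O-])c(N(CC(=O)OCC)Cc2ccccc2)n1`. In a functional assay on A549 cells (Homo sapiens) for antiproliferative activity, read by MTT assay, with a stated time of 48 h (on this read-out lower numbers stand for stronger inhibition and higher numbers for weaker inhibition), compound 1 gives 31900 nM. In this assay compound 2 reaches only the limit of > 100000 nM. In this assay compound 3 likewise reaches only the limit of > 100000 nM, so compound 3 stands at the weak end of what has been measured, with no number of its own. Among the compounds with values here, the one step between measured compounds, a step that the two limits leave unreadable from compound 2 to compound 3, cannot be read because both values rest on (the limit of > 100000 nM in this assay, at which 2 of the 3 values shown sit).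

Compound 4 `CCOC(=O)CN(Cc1ccccc1)c1nc(Nc2cc(OC)c(OC)c(OC)c2)ncc1[N+](=O)[O-]` differs from compound 3 by 3,4,5-trimethoxyphenyl in place of (ethoxycarbonyl)methyl on a nitrogen on an aromatic ring. Within the data shown here, no measured step bears directly on this change, so the expectation rests on compound 1, the only compound with a number, which gives 31900 nM. Compound 3, for its part, has no number of its own in this assay. Compound 4 is therefore expected to gain somewhat, by an estimated at least 4.0-fold lower number from compound 3 to compound 4 (0.60 log units; beyond the scatter), though with wide uncertainty. The estimate for compound 4 in this assay is 25000 nM, within a range of 4000 nM to 100000 nM.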

Compound 4, half-maximal inhibitory concentration: > 100000 nM
Compound 4: a limit, no number; the forecaster's own chance of this, stated with the estimate: 35%; middle value at least 4.0-fold (0.60 log units) from the limit.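

In this assay compound 4 gives only the limit > 100000 nM and no number. Within the data shown here, no step from compound 2 or compound 3 to compound 4 can be read, because all three values rest on one limit: (the limit of > 100000 nM in this assay, at which 3 of the 4 values shown sit). The compounds shown leave open whether 3,4,5-trimethoxyphenyl in place of (ethoxycarbonyl)methyl on a nitrogen on an aromatic ring changes antiproliferative activity at all.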